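The source may hold more compounds than are shown below. What is called first, only, known or untested is meant among the compounds shown, and "the series" means these compounds.

Measured so far in an in vitro ADME assay on microsomes from liver (Mus musculus) for pharmacokinetics, read by LC-MS; on this read-out lower numbers stand for slow clearance and higher numbers for fast clearance:
Compound 1 `Cc1cccc2c1nc(C)n2-c1ccc(C(=O)NC2CC2)s1` gives 66 mL/min/kg.
Compound 2 `Cc1ccc2c(c1)nc(C)n2-c1ccc(C(=O)NC2CC2)s1` gives > 72 mL/min/kg, a limit and not a number.
Compound 3 `Cc1cccc2nc(C)n(-c3ccc(C(=O)NC4CC4)s3)c12` gives > 72 mL/min/kg, a limit and not a number.

Within the data shown here, compound 1 holds the only actual number, at 66 mL/min/kg. The other two readings stand at the limit of > 72 mL/min/kg in this assay, at which 2 of the 3 values shown sit.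

Compound 4 `Cc1nc2c(F)cccc2n1-c1ccc(C(=O)NC2CC2)s1` has fluoro in place of methyl on an aromatic carbon, ortho to a fused ring and meta to a fused ring: fluoro in place of methyl on an aromatic carbon. Among the measured compounds shown here, no measured step covers this change. In this assay the expected 1.2-fold lower number from compound 1 to compound 4 (0.08 log units; within the scatter) stays within the scatter, so no clear direction is expected. A limit reading also remains possible. Compound 4 is estimated at 55 mL/min/kg, with an expected range of 30 mL/min/kg to 72 mL/min/kg.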

Compound 4, clearance: 37 mL/min/kg
Compound 4: middle estimate off by 1.5-fold (0.17 log units), on the high side; the measured number falls inside the stated range.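

In this assay, fluoro in place of methyl on this aromatic carbon, ortho to a fused ring and meta to a fused ring, gives a 1.8-fold lower number from compound 1 to compound 4 (0.25 log units; within the scatter). Among these compounds, this is the first readable step, and at this position the change shows no clear direction in clearance. Compound 4 gives an actual number, so a second compound now stands off the limit: the limit of > 72 mL/min/kg in this assay, at which 2 of the 4 values shown sit.

Steps involving the limit readings cannot be read. Going by these compounds, whether chloro, methoxy or an amine on this carbon would give a clear difference stays open.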